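Acetyl in Place of Fluoro: Expected Cytotoxicity of Compound 3

This account rests on a few compounds, and the source may have more. Where it says the series, first, only, none or still open, it means among the compounds named here.

Compound 1 `Cc1ccc(S(=O)(=O)n2cc(COC3=C/C(=N\c4ccc(Br)cc4)c4ccccc4C3=O)nn2)cc1` gives 4220 nM in a functional assay on HL-60 cells (Homo sapiens) for cytotoxicity, read by MTT assay, with a stated time of 72 h; a lower number here means a stronger inhibitor, a higher number a weaker inhibitor.
Compound 2 `Cc1ccc(S(=O)(=O)n2cc(COC3=C/C(=N\c4ccc(F)cc4)c4ccccc4C3=O)nn2)cc1` gives 7520 nM in this assay.

For the measured compounds named here, compound 2 holds the highest of these two numbers, and its nearest neighbour is compound 1; the only measured step, a 1.8-fold higher number from compound 1 to compound 2 (0.25 log units; within the scatter), lies within the scatter. Compound 3 `CC(=O)c1ccc(/N=C2\C=C(OCc3cn(S(=O)(=O)c4ccc(C)cc4)nn3)C(=O)c3ccccc32)cc1` differs from compound 2 by acetyl in place of fluoro on an aromatic carbon. Going by the values given here, the one measured step swaps a halogen for a halogen and says nothing about an acetyl group, so no measured step bears directly on this change. With nothing pointing either way, no step beyond the scatter is expected, and compound 3 is estimated at 6000 nM, with a range from 2500 nM to 15000 nM. This estimate means the expected step is a 1.3-fold lower number from compound 2 to compound 3 (0.10 log units; within the scatter).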

Compound 3, half-maximal inhibitory concentration: 5300 nM
Compound 3: middle estimate off by 1.1-fold (0.05 log units), on the high side; the range from low to high includes it.
By their numbers in this assay, from the lowest: compounds 1, 3 and 2 (each within the scatter of the next).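

The earlier compounds shown here compared only two halogens, whereas compound 3 places acetyl, a group that is not a halogen, on the same aromatic carbon, para to a large group. Acetyl in place of fluoro gives a 1.4-fold lower number from compound 2 to compound 3 (0.15 log units; within the scatter), and acetyl in place of bromo gives a 1.3-fold higher number from compound 1 to compound 3 (0.10 log units; within the scatter). In this assay, all three compounds therefore stay within the scatter of one another, so this change does not separate them.

From the compounds shown here alone, whether an amine, a carboxylic acid or a longer chain at this position would also stay within this range remains open. No measurement shown gives a reason for these closely spaced values.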